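Swapping the side chain on the triazole of compound 3

The source may report more compounds than this note shows. Statements on the series, on what has been measured and on what is new or still open speak of the compounds shown alone.

Compound 3 `CC(C)[C@H](C(=O)NO)N(CCn1cc(CCCCOc2cccnc2F)nn1)S(=O)(=O)c1ccc(OCCF)cc1` gives the lowest of the three numbers measured in an assay on isolated protein for inhibition of matrix metalloproteinase-9 (Homo sapiens), read by fluorescence, with a stated time of 30 min (a higher number here means a weaker inhibitor, a lower number a stronger inhibitor), with 0.8 nM. Compound 1 `COc1ccc(S(=O)(=O)N(CCn2cc(CN(C)S(=O)(=O)c3ccc(F)cc3)nn2)[C@@H](C(=O)NO)C(C)C)cc1` gives 3 nM in this assay, and compound 2 `Cc1ccc(S(=O)(=O)N(CCn2cc(CCCCOc3cccnc3F)nn2)[C@@H](C(=O)NO)C(C)C)cc1` gives 6 nM. Within the data shown here, the only single-point step among them is a 7.5-fold lower number from compound 2 to compound 3 (0.88 log units; beyond the scatter), which concerns the group on the aryl sulfonyl ring and not the chain on the triazole.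

Compound 4 `CC(C)[C@H](C(=O)NO)N(CCn1cc(CN(C)S(=O)(=O)c2ccc(F)cc2)nn1)S(=O)(=O)c1ccc(OCCF)cc1` keeps the 2-fluoroethoxy of compound 3 and changes the triazole side chain: a group of 12 heavy atoms (7 carbon, 1 nitrogen, 2 oxygen, 1 fluorine, 1 sulfur; one six-membered aromatic ring of carbon only) in place of a group of 11 heavy atoms (8 carbon, 1 nitrogen, 1 oxygen, 1 fluorine; one six-membered aromatic ring with 1 hetero atom), on a saturated chain carbon bound to an aromatic carbon. Among the measured compounds shown here, the group that enters is the same one carried by compound 1, while the group that leaves is the one carried by compound 2; no measured step isolates this exchange, so its effect is not known from the data. Compound 1 with this group gives a low number in this assay, and compound 3 gives a still lower one with the other chain, so a small rise beyond the scatter or no change seems the most plausible outcome. Compound 4 is therefore expected to give about 1.5 nM in this assay, within a range of 0.5 nM to 5 nM, corresponding to an estimated step of a 1.9-fold higher number from compound 3 to compound 4 (0.27 log units; within the scatter).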

Compound 4, half-maximal inhibitory concentration: 11 nM
The estimate for compound 4 lay 7.3-fold (0.87 log units) below the measured number; the whole stated range lies below it.
By their numbers in this assay, from the lowest: compound 3; then compounds 1, 2 and 4 (each within the scatter of the next, the first and the last beyond it).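

The exchange of triazole side chain, read with the 2-fluoroethoxy group held fixed, is a large step in this assay (a 14-fold higher number from compound 3 to compound 4 (1.14 log units; beyond the scatter)), so this position clearly matters and the two groups are not interchangeable here. Adding fluoromethyl to the methoxy of compound 1 also gives a higher number (a 3.7-fold higher number from compound 1 to compound 4 (0.56 log units; beyond the scatter)), while the earlier step to the same 2-fluoroethoxy group, made from a methyl compound carrying the other chain, went the opposite way (a 7.5-fold lower number from compound 2 to compound 3 (0.88 log units; beyond the scatter)), so the 2-fluoroethoxy group does not lower the number with every triazole side chain, although the two steps also start from different groups. Nothing available explains why the step changes direction or why the exchange costs this much.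

The compounds shown leave open which part of the entering group accounts for the step, as the chain and the ring change together. They also leave open how the number would respond to a carboxylic acid or an amine at the end of the triazole chain, or to a methoxy on the aryl sulfonyl ring paired with the chain of compound 3.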